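The source may report more compounds than this note shows. Statements on the series, on what has been measured and on what is new or still open speak of the compounds shown alone.

In a functional assay on A549 cells (Homo sapiens) for antiproliferative activity, read by MTT assay, with a stated time of 72 h (a lower number here means a stronger inhibitor, a higher number a weaker inhibitor), compound 1 (`CCOc1ccc(-c2ccc3ncn(-c4cc(OC)c(OC)c(OC)c4)c3c2)cc1`) reads 8550 nM as a measured number. Compound 2 (`COc1cc(-n2cnc3ccc(-c4ccc(Cl)cc4)cc32)cc(OC)c1OC`) reads > 10000 nM as a limit of the assay, not a number. Compound 3 (`COc1ccc(-c2ccc3ncn(-c4cc(OC)c(OC)c(OC)c4)c3c2)cc1`) differs from compound 2 by methoxy in place of chloro on an aromatic carbon with methoxy in place of chloro on an aromatic carbon. Within the data shown here, the only measured step bearing on this is an at least 1.1-fold higher number from compound 1 to compound 2 (0.06 log units; that floor lies within the scatter) with chloro in place of ethoxy, so its true size remains unknown. A modest move is expected, estimated as an at least 1.6-fold lower number from compound 2 to compound 3 (0.22 log units; that floor lies within the scatter) in this assay overall. For compound 3 the estimate is 6000 nM with an expected range from 1500 nM to 15000 nM around it.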

Compound 3, half-maximal inhibitory concentration: > 10000 nM
Compound 3: no number, only a limit; the forecaster's own chance of this, stated with the estimate: 30%; at least 1.6-fold (0.22 log units) between middle value and limit.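

In this assay compound 3 gives a limit of the assay and not a number, as compound 2 does: the limit of > 10000 nM in this assay, at which 2 of the 3 values shown sit.

So at this position, methoxy in place of chloro yields no measured number, and the step between these two compounds cannot be read. Shortening ethoxy to methoxy gives an at least 1.1-fold higher number from compound 1 to compound 3 (0.06 log units; that floor lies within the scatter), which leaves the true size of that change unknown.

Going by these compounds, whether an amine, a carboxylic acid or a chain longer than ethoxy at this position would give a lower number remains open. On these data alone, the true values of compound 2 and compound 3 also remain open.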